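This account rests on a few compounds, and the source may have more. Where it says the series, first, only, none or still open, it means among the compounds named here.

Measured compounds:
compound 1, `Cc1ccc(-c2nnc(N3CCN(C(=O)CN4CCN(c5cccc(Cl)c5)CC4)CC3)nc2-c2ccc(C)cc2)cc1`, in an ADME assay on NIH3T3 cells (Mus musculus) for cytotoxicity, read by MTT assay, with a stated time of 24 h (a lower number here means a stronger inhibitor, a higher number a weaker inhibitor), compound 1 gives 859000 nM
compound 2, `COc1ccc(N2CCN(CC(=O)N3CCN(c4nnc(-c5ccc(C)cc5)c(-c5ccc(C)cc5)n4)CC3)CC2)cc1`, in this assay compound 2 gives 116000 nM
compound 3, `O=C(CN1CCN(c2cccc(Cl)c2)CC1)N1CCN(c2nnc(-c3ccc(Cl)cc3)c(-c3ccc(Cl)cc3)n2)CC1`, limit only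

The change from compound 1 to compound 2 is 4-methoxyphenyl in place of 3-chlorophenyl on an amine nitrogen in a ring and produced a 7.4-fold lower number from compound 1 to compound 2 (0.87 log units; beyond the scatter). For compound 3 the result is a limit of the assay and not a number, > 803000 nM, which is the limit of > 803000 nM in this assay, at which 1 of the 3 values shown sits. The difference between the core of compound 1 and the core of compound 3 is not broken down here.

Compound 4, `COc1ccc(N2CCN(CC(=O)N3CCN(c4nnc(-c5ccc(Cl)cc5)c(-c5ccc(Cl)cc5)n4)CC3)CC2)cc1`, is not yet measured in this assay. It is related to compound 3 by the same change, (4-methoxyphenyl in place of 3-chlorophenyl on an amine nitrogen in a ring). For compound 4 the expected step is an at least 2.6-fold lower number from compound 3 to compound 4 (0.42 log units; beyond the scatter), resting on a 7.4-fold lower number from compound 1 to compound 2 (0.87 log units; beyond the scatter). Compound 4 is expected near 300000 nM, between 80000 nM and 1000000 nM, with a fair chance that only a limit is reported again.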

Compound 4, half-maximal inhibitory concentration: > 809000 nM
Compound 4: only a limit was reported; the forecaster's own chance of this, stated with the estimate: 40%; middle value at least 2.6-fold (0.43 log units) away from the limit.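

Compound 3 is a limit of this assay, > 803000 nM. Going by these compounds alone, compound 4 is also a limit, > 809000 nM, and no step between the two can be read. Left open is whether 4-methoxyphenyl in place of 3-chlorophenyl lowers the number on the core of compound 3 as it does on the core of compound 1.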